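Extending an amide chain by one methyl on two sulfonate cores

The source may report more compounds than this note shows. Statements on the series, on what has been measured and on what is new or still open speak of the compounds shown alone.

Of the compounds shown here, three have been measured in a functional assay on M21 cells (Homo sapiens) for antiproliferative activity, read by sulforhodamine B assay, with a stated time of 48 h; a lower number here means a stronger inhibitor, a higher number a weaker inhibitor. Compound 1 `CCC(=O)Nc1ccc(S(=O)(=O)Oc2ccccc2I)cc1` gives 11000 nM in this assay. Compound 2 `CC(C)C(=O)Nc1ccc(S(=O)(=O)Oc2ccccc2C(C)C)cc1` carries a different core; the difference between the two cores is not broken down here, and in this assay compound 2 gives 11000 nM. Compound 3 `CC(C)C(=O)Nc1ccc(S(=O)(=O)Oc2ccccc2I)cc1` gives 13000 nM in this assay.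

Compound 3 arises from compound 1 through (methyl in place of hydrogen on a saturated chain carbon bound to a carbonyl carbon and a saturated chain carbon), a change that brought a 1.2-fold higher number from compound 1 to compound 3 (0.07 log units; within the scatter). Compound 4 `CC(C)c1ccccc1OS(=O)(=O)c1ccc(NC(=O)C(C)(C)C)cc1` is not yet measured; it arises from compound 2 through (methyl in place of hydrogen on a saturated chain carbon bound to a carbonyl carbon and two saturated chain carbons). This is the same kind of change, although the place is not identical: in compound 1 the carbon that gains the methyl is bound to a carbonyl carbon and one saturated chain carbon, whereas in compound 2 it is bound to a carbonyl carbon and two saturated chain carbons.

Because the earlier step of this kind gave a 1.2-fold higher number from compound 1 to compound 3 (0.07 log units; within the scatter), compound 4 is expected to show a similarly small step, a 1.2-fold higher number from compound 2 to compound 4 (0.07 log units; within the scatter). The estimated value for compound 4 in this assay is 13000 nM, within a range from 6000 nM to 28000 nM.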

Compound 4, half-maximal inhibitory concentration: 6200 nM
Beside the measured number, compound 4's estimate is 2.1-fold (0.32 log units) above it, and the stated range covers the measured number.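

In this assay, adding one methyl to turn isopropyl into tert-butyl gives a 1.8-fold lower number from compound 2 to compound 4 (0.25 log units; within the scatter). Set beside the earlier step of this kind, the new step does not stand apart from it: the same change on two cores in this assay, a 1.2-fold higher number (0.07 log units; within the scatter) from compound 1 to compound 3 and a 1.8-fold lower number (0.25 log units; within the scatter) from compound 2 to compound 4, 2.1-fold (0.32 log units) apart, within the scatter of two such steps This fits a change that makes no clear difference on either core, but it does not show that the methyl has no effect, or that the result would hold on other cores, since it rests on two pairs, neither step can be given a firm direction, and the carbon gaining the methyl is not the same kind in the two pairs.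

The compounds shown leave open what a tert-butyl group would do on the core of compound 1, where the iodo group stands. They also leave open whether a longer chain, a cyclohexyl ring or an amine in this place on the carbonyl carbon would give a step beyond the scatter.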